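The source may report more compounds than this note shows. Statements on the series, on what has been measured and on what is new or still open speak of the compounds shown alone.

Measured compounds:
compound 1 `CC(C)Nc1ccc2c(-c3cnn(C)c3)n[nH]c2c1` – 46600 nM
compound 2 `COc1ccc(-n2cc(-c3n[nH]c4cc(Cl)c(N[C@@H]5CCNC5)cc34)cn2)cc1` – 300 nM
compound 3 `CNC1CCN(c2ccc3[nH]nc(-c4cnn(C)c4)c3c2)C1` – 432000 nM

In an assay on isolated protein for inhibition of tyrosine-protein kinase receptor UFO (Homo sapiens), with a stated time of 1.5 h (a lower number here means a stronger inhibitor, a higher number a weaker inhibitor), compound 1 gives 46600 nM, the second highest of the three numbers. Compound 3 is the nearest to it and sits higher, outside the usual scatter, with 432000 nM. Compound 2 is the furthest from it and sits far lower, also outside the usual scatter, with 300 nM. None of these three pairs differs in a single place, so the gaps between them say only what the two values show and cannot be read as the effect of one change.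

Compound 4 `Cn1cc(-c2n[nH]c3cc(Nc4ccccc4)ccc23)cn1` is the next compound, not yet measured in this assay. It differs from compound 1 by phenyl in place of isopropyl on a nitrogen on an aromatic ring. Among the measured compounds shown here, no measured pair in the set isolates this change, so the expectation rests on compound 1 alone and on the general spread of the series. The step from compound 1 to compound 4 is expected to be a lowering of the number of modest size, a 3.1-fold lower number from compound 1 to compound 4 (0.49 log units; beyond the scatter), probably beyond the scatter but with wide uncertainty. The estimate for compound 4 in this assay is 15000 nM, expected to fall between 3000 nM and 80000 nM.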

Compound 4, half-maximal inhibitory concentration: 219000 nM
For compound 4 the middle estimate is 15-fold (1.16 log units) below the measured one; the whole stated range lies below it.
By their numbers in this assay, from the lowest: compound 2; then compound 1; then compounds 4 and 3 (each within the scatter of the next).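

Among the compounds shown here, compound 1 and compound 4 form the first pair that differs in one place, so this change can be read directly in this assay: isopropyl to phenyl on a nitrogen on an aromatic ring gives a 4.7-fold higher number from compound 1 to compound 4 (0.67 log units; beyond the scatter) and lies beyond the usual scatter. At this position, then, replacing the branched three-carbon group with the six-carbon aromatic ring makes the compound a weaker inhibitor, although the step is only modest in size. Nothing at hand explains the direction of this step, which stands as an observed difference between two compounds.

Going by these compounds, a single step gives the direction for this one pair and no trend across groups on this nitrogen, so it remains open how a methyl, a longer alkyl chain or a cyclohexyl group would compare with isopropyl. On these data alone, it also remains open whether an amine or a carboxylic acid carried on the phenyl would shift the number of compound 4, and whether the same exchange would give a similar step on a different core.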